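A few compounds are considered here, and "the series" means these few. Any claim that something is new, unique, unknown or untested is made for them only; others in the source may bear on it.

Compound 1 `C#C[C@]1(O)[C@@H](CO)O[C@@H](n2ccc(=O)[nH]c2=O)[C@@H]1O`, in a functional assay on L1210 cells (Mus musculus), read by MTT assay; a lower number here means a stronger inhibitor, a higher number a weaker inhibitor: > 350000 nM; 130 nM (2 entries).
Compound 2 `C=C[C@@]1(O)[C@@H](CO)O[C@@H](n2ccc(=O)[nH]c2=O)[C@@H]1O`, in this assay: 148000 nM.
Compound 3 `C#CC[C@@]1(O)[C@@H](CO)O[C@@H](n2ccc(=O)[nH]c2=O)[C@@H]1O`: not yet measured.

Compound 1 has two entries in this assay, one of which is a limit of the assay and not a number (the several entries of compound 1 in this assay, > 350000 nM; 130 nM (2 entries)). Compound 2 gives 148000 nM, the only single number shown for it, while one further entry carries no single number. Compound 3 differs from compound 2 by propargyl in place of vinyl on a saturated ring carbon. Among the measured compounds shown here, no measured step between two compounds is available for comparison, so the step from compound 2 to compound 3 is expected to stay within the scatter, at a 1.4-fold higher number from compound 2 to compound 3 (0.13 log units; within the scatter). Compound 3 is therefore estimated at 200000 nM, with a range from 50000 nM to 350000 nM.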

Compound 3, half-maximal inhibitory concentration: > 350000 nM
Compound 3: a limit, no number (the forecaster's own chance of this, stated with the estimate: 40%); middle value at least 1.7-fold (0.24 log units) away from the limit.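

Among the compounds shown here, the first readable step at this position in this assay is an at least 2.3-fold higher number from compound 2 to compound 3 (0.37 log units; beyond the scatter). On this saturated ring carbon, propargyl in place of vinyl therefore gives weaker inhibition, with one more heavy carbon in the group and a triple bond in place of the double bond. Going by these compounds, compound 3 gives > 350000 nM, which is a limit of the assay and not a number, so the full size of the step stays unknown.

The compounds shown leave open how a longer chain, an amine or a carboxylic acid at this position would read. Compound 1 also gives no single reference value for the series: the several entries of compound 1 in this assay, > 350000 nM; 130 nM (2 entries)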